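A few compounds are considered here, and "the series" means these few. Any claim that something is new, unique, unknown or untested is made for them only; others in the source may bear on it.

Three measured compounds share one core and differ only in the group attached to an aromatic carbon of the five-membered aromatic ring with 2 nitrogen. Compound 1 `CCCn1c(=O)c2nc(CC(C)(C)C)[nH]c2n(CCC)c1=O` carries a neopentyl group there, and in an assay on cell membranes for binding affinity to adenosine receptor A1 (Cavia porcellus), read by radioligand binding (on this read-out lower numbers stand for stronger inhibition and higher numbers for weaker inhibition), compound 1 gives 49 nM. Compound 2 `CCCn1c(=O)c2nc(C(C)(C)CCC)[nH]c2n(CCC)c1=O` carries 1,1-dimethylbutyl, and in this assay compound 2 gives 25 nM. Compound 3 `CCCn1c(=O)c2nc(C(C)(C)C)[nH]c2n(CCC)c1=O` carries tert-butyl, and in this assay compound 3 gives 31 nM. Among the three numbers compound 3 stands second highest; its nearest neighbour is compound 2 and its furthest is compound 1, and both gaps lie within the scatter, as a 1.2-fold higher number from compound 2 to compound 3 (0.09 log units; within the scatter) and a 1.6-fold lower number from compound 1 to compound 3 (0.20 log units; within the scatter) show.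

Compound 4 `CCCn1c(=O)c2nc(CC3CC3)[nH]c2n(CCC)c1=O` is the next member of the series. It differs from compound 3 by cyclopropylmethyl in place of tert-butyl on an aromatic carbon. Among the measured compounds shown here, every measured step so far exchanged the group on this same carbon, and none of them left the scatter: a 2.0-fold lower number from compound 1 to compound 2 (0.29 log units; within the scatter), a 1.6-fold lower number from compound 1 to compound 3 (0.20 log units; within the scatter) and a 1.2-fold higher number from compound 2 to compound 3 (0.09 log units; within the scatter). On that basis no step beyond the scatter is expected in this assay for compound 4, and the estimated step from compound 3 to compound 4 is a 1.1-fold higher number from compound 3 to compound 4 (0.05 log units; within the scatter). For compound 4 the expected value in this assay is 35 nM, with a range from 15 nM to 80 nM.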

Compound 4, inhibition constant: 120 nM
Compound 4: middle estimate off by 3.4-fold (0.54 log units), on the low side, and the stated range ends below it.
By their numbers in this assay, from the lowest: compounds 2, 3 and 1 (each within the scatter of the next); then compound 4.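

In this assay this position proves not to be indifferent to the group it carries, even though the exchanges among neopentyl, 1,1-dimethylbutyl and tert-butyl all stayed within the scatter. Cyclopropylmethyl in place of tert-butyl gives a 3.9-fold higher number from compound 3 to compound 4 (0.59 log units; beyond the scatter) even though the count of heavy atoms stays the same and both groups are carbon only, and in place of 1,1-dimethylbutyl it gives a 4.8-fold higher number from compound 2 to compound 4 (0.68 log units; beyond the scatter) on the same aromatic carbon. The comparison with neopentyl, where cyclopropyl replaces tert-butyl on the saturated chain carbon bound to the aromatic carbon, gives a 2.4-fold higher number from compound 1 to compound 4 (0.39 log units; beyond the scatter) and so shows that keeping that chain carbon does not keep the number; compound 4 is also the only one of the four with a ring in this group, though a single compound sets no pattern.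

Nothing shown here accounts for the rise in the number. Going by these compounds, it remains open whether cyclopropyl on that aromatic carbon, cyclobutyl or a straight butyl chain would stand with compound 4 or with compounds 1, 2 and 3.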